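The source may hold more compounds than are shown below. What is called first, only, known or untested is meant among the compounds shown, and "the series" means these compounds.

Compound 2 `COC[C@H]1CN(c2ccc(OCCO)cc2)C(=O)O1` gives 0.77 in a physicochemical assay for lipophilicity; on this read-out lower numbers stand for lower lipophilicity and higher numbers for higher lipophilicity. Compound 1 `COC[C@H]1CN(c2ccc(OCC(C)O)cc2)C(=O)O1` differs from it by methyl in place of hydrogen on a saturated chain carbon bound to an oxygen on a saturated carbon and a saturated chain carbon, and in this assay compound 1 gives 1.17, a step of a number 0.40 log units higher from compound 2 to compound 1 (beyond the scatter). Compound 3 `COC[C@H]1CN(c2ccc(OCCCCO)cc2)C(=O)O1` carries a different core, set apart from that of compound 2 by 2-hydroxyethyl in place of hydroxy on a saturated chain carbon, two bonds along the chain from an oxygen on an aromatic ring; in this assay compound 3 gives 1.84, a step of a number 1.07 log units higher from compound 2 to compound 3 (beyond the scatter), and also a number 0.67 log units higher from compound 1 to compound 3 (beyond the scatter). Compound 4 `COC[C@H]1CN(c2ccc(OCCCC(C)O)cc2)C(=O)O1`, not yet measured, stands to compound 3 as compound 1 stands to compound 2: the difference is methyl in place of hydrogen on a saturated chain carbon bound to an oxygen on a saturated carbon and a saturated chain carbon, the same change at the same place in the words given. Among the compounds with values here, on the strength of the one earlier step, a number 0.40 log units higher from compound 2 to compound 1 (beyond the scatter), the step from compound 3 to compound 4 is expected to be a number 0.40 log units higher from compound 3 to compound 4 (beyond the scatter). Compound 4 is therefore estimated at 2.24, with a range from 1.95 to 2.55.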

Compound 4, partition coefficient: 2.27
Compound 4: the middle estimate sits 0.03 log units below what was measured; the measured number falls inside the stated range.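

In this assay the methyl in place of hydrogen gave a number 0.43 log units higher from compound 3 to compound 4 (beyond the scatter) and so matched in direction the earlier a number 0.40 log units higher from compound 2 to compound 1 (beyond the scatter) on the core of compound 2, with both steps beyond the scatter. The wider comparisons, a number 1.50 log units higher from compound 2 to compound 4 (beyond the scatter) and a number 1.10 log units higher from compound 1 to compound 4 (beyond the scatter) as well, place compound 4 highest of the four compounds. This shows the change carrying between these two cores only, and it does not show that it would carry to any other core, while nothing available accounts for the size of the step.

The compounds shown leave open whether the methyl step would hold if an amine or a carboxylic acid stood in place of the hydroxy. They also leave open what it would do on a chain longer than 3-hydroxybutyl.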